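Replacing an Aryl Ring With a Styryl Arm

This account rests on a few compounds, and the source may have more. Where it says the series, first, only, none or still open, it means among the compounds named here.

Compound 1 `CCOc1cccc(-c2ccc(CN(C(=O)C3CCCCC3)c3cccc(/C=C/C(=O)OC)c3)cc2)c1` gives 147 nM in an assay on isolated protein with Bile acid receptor (Homo sapiens) as the target (a higher number here means that more compound is needed for the effect, a lower number that less compound is needed), the lowest of the three numbers seen so far, though both others lie within the scatter of it: compound 2 `CCOc1cccc(-c2ccc(CN(C(=O)C(C)C)c3cccc(/C=C/C(=O)OC)c3)cc2)c1` gives 173 nM and compound 3 `COC(=O)/C=C/c1cccc(N(Cc2ccc(-c3cccc(OC(F)(F)F)c3)cc2)C(=O)C(C)C)c1` gives 247 nM. The step of a 1.2-fold higher number from compound 1 to compound 2 (0.07 log units; within the scatter) and the step of a 1.4-fold higher number from compound 2 to compound 3 (0.15 log units; within the scatter) are each within the scatter. Compound 4 `COC(=O)/C=C/c1cccc(N(Cc2ccc(/C=C/c3ccc(F)cc3)cc2)C(=O)C2CCCCC2)c1` differs from compound 1 by 2-(4-fluorophenyl)ethenyl in place of 3-ethoxyphenyl on an aromatic carbon, placed para to a large group. Among the measured compounds shown here, only the change from compound 2 to compound 3 touches the same region, and it swapped one group on the oxygen for another rather than the whole ring; no measured step tests an ethenyl link. The number for compound 4 is therefore expected to move only modestly, most likely upward, giving a 1.8-fold higher number from compound 1 to compound 4 (0.25 log units; within the scatter). Compound 4 is estimated at 260 nM in this assay, between 100 nM and 700 nM.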

Compound 4, half-maximal effective concentration: 185 nM
For compound 4 the middle estimate is 1.4-fold (0.15 log units) above the measured one; measured number inside the range.
By their numbers in this assay, from the lowest: compounds 1, 2, 4 and 3 (each within the scatter of the next).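

Replacing the whole 3-ethoxyphenyl with 2-(4-fluorophenyl)ethenyl on this aromatic carbon gives a 1.3-fold higher number from compound 1 to compound 4 (0.10 log units; within the scatter) in this assay. The earlier step at this end of the molecule changed only the group on the oxygen, whereas this one removes that oxygen and adds a double bond outside aromatic rings, and the step still stays within the scatter. Nothing available explains this result.

The contributions of the double bond and the fluorine remain unseparated, as they enter together. As far as these compounds go, whether an amine or a carboxylic acid on that ring would also stay within the scatter remains open.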